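Aryl sulfonamides on a shared core: working notes

The compounds below may be only part of what the source reports. "The series", "measured", "known", "first", "only" and "open" are said of these compounds alone.

Measured compounds:
compound 1 `O=S(=O)(Nc1ccc2oc(-c3ccccc3)nc2c1)c1cccs1` — 90000 nM
compound 2 `COc1ccccc1S(=O)(=O)Nc1ccc(-c2nc3ccccc3o2)cc1` — > 100000 nM
compound 3 `Cc1ccc(S(=O)(=O)Nc2ccc(-c3nc4ccccc4o3)cc2)cc1` — > 100000 nM

Going by the values given here, in an assay on cells for inhibition of HSP60/HSP10 (Homo sapiens), with a stated time of 60 min (on this read-out lower numbers stand for stronger inhibition and higher numbers for weaker inhibition), compound 1 gives 90000 nM, the only actual number among the three values shown. Compound 2 gives only a limit of the assay, > 100000 nM. Compound 3 likewise gives only a limit, > 100000 nM. Among the compounds with values here, the single step between measured compounds, a step that the two limits leave unreadable from compound 2 to compound 3, cannot be read in size because both of its ends sit at the limit of > 100000 nM in this assay, at which 2 of the 3 values shown sit.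

Compound 4 `COc1ccc(Cl)cc1S(=O)(=O)Nc1ccc2oc(-c3ccccc3)nc2c1` differs from compound 1 by 5-chloro-2-methoxyphenyl in place of thiophen-2-yl on a sulfonyl sulfur. Within the data shown here, no measured step bears on this change: the one step available concerns a different exchange on the sulfonyl sulfur, and its size is unreadable. Among the measured compounds shown here, all three measured compounds, whatever the group on the sulfonyl sulfur, are weak or at the limit, which is the only guide. Compound 4 is therefore expected to give about 100000 nM, in a range from 40000 nM to 300000 nM. The expected step of a 1.1-fold higher number from compound 1 to compound 4 (0.05 log units; within the scatter) lies within the scatter, with a fair chance that only a limit is reported.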

Compound 4, half-maximal inhibitory concentration: > 100000 nM
Compound 4: a limit, no number; the forecaster's own chance of this, stated with the estimate: 55%; the middle value sits exactly at the limit.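

The exchange on the sulfonyl sulfur gives an at least 1.1-fold higher number from compound 1 to compound 4 (0.04 log units; that floor lies within the scatter). On these data alone, the value of compound 4 is a limit of the assay and not a number, so the size of this step stays unknown, and on the core of compound 1 the 5-chloro-2-methoxyphenyl group shows no gain over thiophen-2-yl. With this result, the series sits mostly at one boundary: the limit of > 100000 nM in this assay, at which 3 of the 4 values shown sit.

Open, as far as these compounds go, is whether any group on the sulfonyl sulfur on this core can bring a value clearly under that limit, for example a 4-aminophenyl group or a phenyl ring carrying a carboxylic acid. Also open, from the compounds shown here alone, is how far compound 4 lies from compound 1, and whether thiophen-2-yl itself matters, as no other five-membered aromatic ring appears in this position.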